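The source may report more compounds than this note shows. Statements on the series, on what has been measured and on what is new or still open speak of the compounds shown alone.

Three compounds that share one core were tested in a functional assay on MG-63 cells (Homo sapiens) for inhibition, read by CCK-8 assay, with a stated time of 72 h, tested at 1 uM; on this read-out higher numbers stand for more inhibition at the one concentration tested (going by the name of the read-out) and lower numbers for less inhibition. Compound 1 `COc1cccc(OC)c1N1C(=O)CSC1c1cccc(C(=O)NCCCCc2ccccc2)c1` gives 80%. Compound 3 `CCOc1ccccc1N1C(=O)C(C)SC1c1cccc(C(=O)NCCCCc2ccccc2)c1` gives 92%, and compound 2 `O=C(NCCCCc1ccccc1)c1cccc(C2OCC(=O)N2c2cccc(F)c2)c1` gives 66%. Among these three numbers compound 1 stands second highest: compound 3 lies above it by a gap beyond the usual scatter, and compound 2 lies below it by a gap that is also beyond the scatter. Compound 4 `O=C(NCCCCc1ccccc1)c1cccc(C2SCC(=O)N2c2ccccc2)c1` has not yet been measured. It differs from compound 1 in a single place: phenyl in place of 2,6-dimethoxyphenyl on an amide-type nitrogen in a ring. Among the measured compounds shown here, no measured pair shows this exact change, so its size is uncertain; a small drop in this assay, close to the edge of the scatter, is expected. For compound 4 the estimate is 70%, with a range from 52% to 86%. This corresponds to an expected step of a number 10 percentage points lower from compound 1 to compound 4 (within the scatter).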

Compound 4, a percentage reported as inhibition, at one concentration (the size of the read-out at that concentration, not a potency): 89%
Compound 4: middle estimate off by 19 percentage points, on the low side; measured number outside the range, above it.
By their numbers in this assay, from the lowest: compound 2; then compounds 1, 4 and 3 (each within the scatter of the next, the first and the last beyond it).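

In this assay, phenyl in place of 2,6-dimethoxyphenyl on the amide-type nitrogen in the ring gives a number 9 percentage points higher from compound 1 to compound 4 (within the scatter). At this position, then, the two methoxy groups are not needed to keep inhibition at the one concentration tested, since the plain phenyl stays within the scatter. Nothing measured here explains why the number stays level across this change. Still open, on these data alone, is whether a larger change on this phenyl, such as an added amine or a carboxylic acid, would also leave the number level. A single step cannot show how large a change leaves the number level.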